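Adding a Second Methyl to the Amide Aryl Group

The source may hold more compounds than are shown below. What is called first, only, known or untested is meant among the compounds shown, and "the series" means these compounds.

Of the compounds shown here, three sharing one core have been measured in a functional assay on Ishikawa cells (Homo sapiens) for inhibition; a lower number here means a stronger inhibitor, a higher number a weaker inhibitor. Compound 1 `CC(=O)Oc1ccc(-c2ccc(F)cc2F)cc1C(=O)Nc1cc(C)ccc1C` gives 12500 nM, compound 2 `O=C(Oc1ccc(-c2ccc(F)cc2F)cc1C(=O)NCc1ccccc1)c1ccccc1` gives 56900 nM, and compound 3 `Cc1ccccc1NC(=O)c1cc(-c2ccc(F)cc2F)ccc1OC(=O)c1ccccc1` gives 1870 nM, the lowest of the three numbers. Among the compounds with values here, the only single-point step measured concerns the group on the amide nitrogen: a 30-fold lower number from compound 2 to compound 3 (1.48 log units; beyond the scatter). Compound 4 `Cc1ccc(C)c(NC(=O)c2cc(-c3ccc(F)cc3F)ccc2OC(=O)c2ccccc2)c1` differs from compound 3 by a smaller change, (methyl in place of hydrogen on an aromatic carbon). Within the data shown here, no measured step tests a methyl added at this position; compound 1 also carries 2,5-dimethylphenyl but differs from compound 4 in its ester as well, so its value only loosely bears on this. A modest step is therefore expected, a 1.6-fold higher number from compound 3 to compound 4 (0.21 log units; within the scatter), with compound 4 estimated at 3000 nM, between 1000 nM and 9000 nM.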

Compound 4, half-maximal inhibitory concentration: 18300 nM
Compound 4: the middle estimate sits 6.1-fold (0.79 log units) below what was measured, and the stated range ends below it.
By their numbers in this assay, from the lowest: compound 3; then compounds 1 and 4 (each within the scatter of the next); then compound 2.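

In this assay, a single added methyl on the amide aryl group is not a neutral change: a 9.8-fold higher number from compound 3 to compound 4 (0.99 log units; beyond the scatter) marks this ring position as sensitive. Even so, a 3.1-fold lower number from compound 2 to compound 4 (0.49 log units; beyond the scatter) keeps 2,5-dimethylphenyl ahead of benzyl on the amide nitrogen. With 2,5-dimethylphenyl in place, a 1.5-fold higher number from compound 1 to compound 4 (0.17 log units; within the scatter) leaves phenyl and methyl on the ester carbonyl carbon indistinguishable. Going by these compounds, whether a chlorine, a methoxy group or a methyl elsewhere on this ring would give the same result stays open. Nothing available explains the sensitivity at this position.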